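The compounds below may be only part of what the source reports. "The series", "measured", "known", "first", "only" and "open" are said of these compounds alone.

Measured compounds:
compound 1 `COc1ccc(-c2cc(C(=O)/C=C/c3ccccc3)nc3cc(-c4ccccc4)nn23)cc1OC` — 18600 nM
compound 2 `COc1cc(-c2cc(C(=O)/C=C/c3ccccc3)nc3cc(-c4ccccc4)nn23)cc(OC)c1OC` — 18000 nM
compound 3 `COc1ccc(/C=C/C(=O)c2cc(-c3cc(OC)c(OC)c(OC)c3)n3nc(-c4ccccc4)cc3n2)cc1OC` — 20500 nM

All three were tested in a functional assay on A549 cells (Homo sapiens) for antiproliferative activity, read by MTT assay, with a stated time of 24 h; on this read-out higher numbers stand for weaker inhibition and lower numbers for stronger inhibition. Compound 2 gives the smallest number of the three, but its gaps to compound 1 and to compound 3 both lie within the scatter, so nothing separates them. Compound 4 `COc1cc(-c2cc(/C=C/C(=O)c3ccc(Cl)cc3)nc3cc(-c4ccccc4)nn23)cc(OC)c1OC` differs from compound 2 by 2-((4-chlorophenyl)carbonyl)ethenyl in place of (2-phenylethenyl)carbonyl on an aromatic carbon. Within the data shown here, no measured step matches this change; the nearest in kind is a 1.1-fold higher number from compound 2 to compound 3 (0.06 log units; within the scatter), a change to the same part of the molecule that stayed within the scatter, and a 1.0-fold lower number from compound 1 to compound 2 (0.01 log units; within the scatter) likewise stayed within it. The step is therefore expected to be no change at the digits printed from compound 2 to compound 4 (within the scatter), nothing beyond the scatter. Compound 4 is estimated to give 18000 nM, in the range 8000 nM to 40000 nM.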

Compound 4, half-maximal inhibitory concentration: 15500 nM
The estimate for compound 4 lay 1.2-fold (0.06 log units) above the measured number; the measured number falls inside the stated range.
By their numbers in this assay, from the lowest: compounds 4, 2, 1 and 3 (each within the scatter of the next).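

Replacing (2-phenylethenyl)carbonyl with 2-((4-chlorophenyl)carbonyl)ethenyl reverses the order of the carbonyl and the ethenyl in the chain and also adds a chlorine, yet this assay shows a 1.2-fold lower number from compound 2 to compound 4 (0.06 log units; within the scatter). Among these compounds, the earlier compounds varied only the methoxy groups on the aromatic rings, so this is the first sign that the chain itself can be reversed without a change beyond the scatter. No available evidence bears on this result.

As far as these compounds go, the two changes arrive together, so their separate contributions remain unknown, and they could even be offsetting each other. From the compounds shown here alone, it also remains open how an amine or a carboxylic acid in place of the chlorine would read.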